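The source may report more compounds than this note shows. Statements on the series, on what has been measured and on what is new or still open speak of the compounds shown alone.

Compound 1 `CSc1nc(NCc2ccc(-c3ccccn3)cc2)c2[nH]nc(C(C)C)c2n1` is the weakest growth inhibitor among the three compounds measured in a functional assay on HT cells (Homo sapiens) for antiproliferative activity, read by fluorescence, with a stated time of 72 h; a higher number here means a weaker inhibitor of growth, a lower number a stronger inhibitor of growth: compound 1 gives 783 nM, the highest of the three numbers. Its two neighbours share the same core and differ only at the group on the sulfur. Compound 2 `CC(C)c1n[nH]c2c(NCc3ccc(-c4ccccn4)cc3)nc(SCCNC(N)=O)nc12` gives 240 nM, and compound 3 `CC(C)c1n[nH]c2c(NCc3ccc(-c4ccccn4)cc3)nc(SCCn3ccnc3)nc12` gives 155 nM. The two steps away from compound 1 both enlarge the methyl on the sulfur with a group carrying nitrogen: a 3.3-fold lower number from compound 1 to compound 2 (0.51 log units; beyond the scatter), and a 5.1-fold lower number from compound 1 to compound 3 (0.70 log units; beyond the scatter). Between the two enlarged compounds the difference is small: a 1.5-fold lower number from compound 2 to compound 3 (0.19 log units; within the scatter).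

Compound 4 `CC(C)c1n[nH]c2c(NCc3ccc(-c4ccccn4)cc3)nc(SC3CCCCC3N)nc12` is the next change in this direction. 2-aminocyclohexyl in place of methyl on a sulfur The entering group brings one hydrogen-bond donor and one hydrogen-bond acceptor, as the ureidomethyl and imidazolylmethyl groups did, so the two earlier steps bear on this one. Both were modest lowerings beyond the scatter, and a lowering of similar size is therefore expected here, with the ring making the size less certain. For compound 4 the expected step is a 3.1-fold lower number from compound 1 to compound 4 (0.50 log units; beyond the scatter), and the estimate for compound 4 is 250 nM, with a range from 90 nM to 700 nM.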

Compound 4, concentration for 50% growth inhibition: 139 nM
For compound 4 the middle estimate is 1.8-fold (0.25 log units) above the measured one, within the range that was stated.
By their numbers in this assay, from the lowest: compounds 4, 3 and 2 (each within the scatter of the next); then compound 1.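

In this assay the methyl on the sulfur can give way to a much larger group built on a six-membered non-aromatic ring of carbon only, and the number still falls, with a 5.6-fold lower number from compound 1 to compound 4 (0.75 log units; beyond the scatter) as the step, so this position is not limited to open chains such as those of compound 2 and compound 3. Changing the kind of group also makes no readable difference among the three larger groups, since both a 1.1-fold lower number from compound 3 to compound 4 (0.05 log units; within the scatter) and a 1.7-fold lower number from compound 2 to compound 4 (0.24 log units; within the scatter) stay within the scatter, and all three stand apart from the methyl of compound 1 in the same direction. No measurement here explains why these quite different groups end up level.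

As far as these compounds go, it stays open whether the step to compound 4 belongs to the ring or to its amine, a question that a plain cyclohexyl on the sulfur would address. A simple ethyl chain or a chain ending in a carboxylic acid would show whether a nitrogen on this group matters at all.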